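A further methoxy on a potent growth inhibitor

The compounds below may be only part of what the source reports. "The series", "measured", "known", "first", "only" and "open" are said of these compounds alone.

In a functional assay on MCF7 cells (Homo sapiens) for antiproliferative activity (a lower number here means a stronger inhibitor of growth, a higher number a weaker inhibitor of growth), compound 3 (`COc1ccc(-c2nc3cc(F)ccc3s2)cc1OC`) gives < 0.1 nM as its reading, which is a limit and not a number. Compound 4 (`COc1cc(-c2nc3cc(F)ccc3s2)cc(OC)c1OC`) differs from it by methoxy in place of hydrogen on an aromatic carbon. For the measured compounds named here, no measured step makes this exact change, and two bear on it only indirectly. Compound 1 (`COc1ccc(-c2nc3ccccc3s2)cc1OC`) lacks the fluoro and gives 52700 nM, a change seen as an at least 520000-fold lower number from compound 1 to compound 3 (5.72 log units; beyond the scatter). Compound 2 (`COc1ccc(-c2nc3cc(F)ccc3s2)cc1C`) carries methyl in place of methoxy and gives 48 nM, a change seen as an at least 480-fold lower number from compound 2 to compound 3 (2.68 log units; beyond the scatter). Both steps are large, and the second falls on the aromatic ring that changes in compound 4. A weaker reading is therefore expected, as an at least 50-fold higher number from compound 3 to compound 4 (1.69 log units; beyond the scatter), although its size is uncertain. For compound 4 the estimated value is 5 nM, with an expected range of 0.1 nM to 500 nM.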

Compound 4, concentration for 50% growth inhibition: 1.9 nM
Compound 4: middle estimate off by 2.6-fold (0.42 log units), on the high side, within the range that was stated.
By their numbers in this assay, from the lowest: compound 4; then compound 2; then compound 1. At a limit, below all of these: compound 3.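

In this assay, for the compounds shown here, methoxy in place of hydrogen on this aromatic carbon, ortho to a methoxy group, gives an at least 19-fold higher number from compound 3 to compound 4 (1.27 log units; beyond the scatter), the first direct reading of this change. It shows that this position does not take the added methoxy without a loss beyond the scatter. The reading of compound 3 is a limit, so the step's true size stays unknown: the limit of < 0.1 nM in this assay, at which 1 of the 4 values shown sits.

On these data alone, whether a hydroxyl or an amine on this carbon would read closer to compound 3 stays open. So does the effect of this methoxy on the core of compound 1, which lacks the fluoro.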